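One More Halogen on Compound 3

The source may report more compounds than this note shows. Statements on the series, on what has been measured and on what is new or still open speak of the compounds shown alone.

Compound 3 `CCOC(=O)c1sc(-c2cccc(NC(=O)c3ccc(Cl)cc3)c2)nc1Nc1ccc(N2CCN(C)CC2)cc1` gives 46.9% in a functional assay on Ramos cells (Homo sapiens) for antiproliferative activity, read by CCK-8 assay, with a stated time of 72 h, tested at 40 uM (a higher number here means more inhibition at the concentration tested (going by the name of the read-out), a lower number less inhibition), the second highest of three numbers. Compound 2 `CCOC(=O)c1sc(-c2cccc(NC(=O)c3ccccc3F)c2)nc1Nc1ccc(N2CCN(C)CC2)cc1` gives 96.4%, and compound 1 `CCOC(=O)c1sc(-c2cccc(NC(=O)c3ccc(C(C)(C)C)cc3)c2)nc1Nc1ccc(N2CCN(C)CC2)cc1` gives 21.2%. Compound 4 `CCOC(=O)c1sc(-c2cccc(NC(=O)c3ccc(F)c(Cl)c3)c2)nc1Nc1ccc(N2CCN(C)CC2)cc1` differs from compound 3 by a single change: 3-chloro-4-fluorophenyl in place of 4-chlorophenyl on a carbonyl carbon. For the measured compounds named here, two measured steps bear on it. The step of a number 49.5 percentage points lower from compound 2 to compound 3 (beyond the scatter) shows a large loss when 4-chlorophenyl replaced 2-fluorophenyl. The step of a number 25.7 percentage points higher from compound 1 to compound 3 (beyond the scatter) shows a modest gain from chloro in place of tert-butyl. Keeping the chloro and adding a fluorine is therefore expected to bring a moderate rise in this assay, so compound 4 is estimated at 62%, between 38% and 86%, an expected step of a number 15.1 percentage points higher from compound 3 to compound 4 (beyond the scatter).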

Compound 4, a percentage reported as inhibition, at one concentration (the size of the read-out at that concentration, not a potency): 72.5%
The estimate for compound 4 lay 10.5 percentage points below the measured number; the range from low to high includes it.
By their numbers in this assay, from the lowest: compound 1; then compound 3; then compound 4; then compound 2.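

In this assay, adding a fluorine while keeping the chloro gives a number 25.6 percentage points higher from compound 3 to compound 4 (beyond the scatter), so this ring on the amide carbonyl can still gain from one extra halogen. Against the bulkier 4-(tert-butyl)phenyl group, the 3-chloro-4-fluorophenyl group gives a number 51.3 percentage points higher from compound 1 to compound 4 (beyond the scatter), but against the 2-fluorophenyl group it gives a number 23.9 percentage points lower from compound 2 to compound 4 (beyond the scatter), so a second halogen does not by itself match that single fluorine. Nothing shown here explains these differences. Going by these compounds, whether an amine or a carboxylic acid on this ring would keep the inhibition remains open.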